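The source may hold more compounds than are shown below. What is called first, only, known or untested is meant among the compounds shown, and "the series" means these compounds.

Measured so far:
compound 1 `CN(C)CC(=O)N1CCC(NS(=O)(=O)c2cc(S(=O)(=O)c3ccccc3)ccc2C(F)(F)F)CC1` — 100000 nM
compound 2 `O=C(CN1CCNCC1)N1CCC(NS(=O)(=O)c2cc(S(=O)(=O)c3ccccc3)ccc2C(F)(F)F)CC1` — 50000 nM
compound 3 `O=C1CC[C@@H](C(=O)N2CCC(NS(=O)(=O)c3cc(S(=O)(=O)c4ccccc4)ccc3C(F)(F)F)CC2)N1` — 100000 nM

In a physicochemical assay for solubility (on this read-out higher numbers stand for higher solubility and lower numbers for lower solubility), compound 1 stands level with compound 3, the two together at the top of three numbers; compound 2 is the furthest from it, a 2.0-fold lower number from compound 1 to compound 2 (0.30 log units; within the scatter). Every step among the three measured compounds lies within the scatter: no change at the digits printed from compound 1 to compound 3 (within the scatter) and a 2.0-fold higher number from compound 2 to compound 3 (0.30 log units; within the scatter).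

Compound 4 `CC(C)C(=O)N1CCC[C@H]1C(=O)N1CCC(NS(=O)(=O)c2cc(S(=O)(=O)c3ccccc3)ccc2C(F)(F)F)CC1` is not yet measured. Its change from compound 1 is 1-(isopropylcarbonyl)pyrrolidin-2-yl in place of (dimethylamino)methyl on a carbonyl carbon. Among the compounds with values here, the steps that bear on it are those that also vary the group on the carbonyl carbon: from compound 1 to compound 2 and from compound 1 to compound 3, both within the scatter. Neither brings in a 1-(isopropylcarbonyl)pyrrolidin-2-yl group; the closest measured relative is the 5-oxopyrrolidin-2-yl of compound 3, and that step read no change at the digits printed from compound 1 to compound 3 (within the scatter). Within the data shown here, with no measured step that matches the full change, the expectation for compound 4 in this assay is a step of a 2.0-fold lower number from compound 1 to compound 4 (0.30 log units; within the scatter), which cannot be separated from the scatter with confidence. Compound 4 is therefore estimated at 50000 nM, within a range of 15000 nM to 150000 nM.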

Compound 4, solubility: 100000 nM
Estimate against measurement, compound 4: 2.0-fold (0.30 log units) below; low and high end bracket the measured number.
By their numbers in this assay, from the lowest: compounds 2, 1, 3 and 4 (each within the scatter of the next).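

In this assay the carbonyl carbon on the amide-type ring nitrogen accepts a 1-(isopropylcarbonyl)pyrrolidin-2-yl group, with 10 heavy atoms where (dimethylamino)methyl has 4, and the step stays within the scatter (no change at the digits printed from compound 1 to compound 4 (within the scatter)). The comparison with the other ring-bearing group, 5-oxopyrrolidin-2-yl, reads the same way (no change at the digits printed from compound 3 to compound 4 (within the scatter)), and the comparison with (piperazin-1-yl)methyl also stays within the scatter (a 2.0-fold higher number from compound 2 to compound 4 (0.30 log units; within the scatter)). The earlier compounds shown here reached only smaller groups at this place, so compound 4 extends the tolerated range to the isopropylcarbonyl-capped pyrrolidine, and all four groups now sit within the scatter of one another, with no order among them.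

A carboxylic acid or a long unbranched alkyl chain on this carbonyl carbon would test whether the read-out moves beyond the scatter at this place, and the four compounds shown, all sharing one core, cannot say whether it would. No measurement available here gives a reason for these readings, or for their closeness.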